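A few compounds are considered here, and "the series" means these few. Any claim that something is new, unique, unknown or untested is made for them only; others in the source may bear on it.

Measured compounds:

Compound 1, `CC(=O)Oc1ccccc1C(=O)NCC[Se]C#N`, gives 2900 nM in a functional assay on UACC-903 cells (Homo sapiens) for antiproliferative activity, read by MTT assay, with a stated time of 72 h; on this read-out higher numbers stand for weaker inhibition and lower numbers for stronger inhibition.
Compound 2, `CC(=O)Oc1ccccc1C(=O)OCC[Se]C#N`, gives 17600 nM.
Compound 3, `CC(=O)Oc1ccccc1C(=O)[Se]CC[Se]C#N`, gives 12700 nM.

Among these three, compound 3 stands second highest; its nearest neighbour is compound 2, from which it differs only within the scatter, while compound 1 sits well below it.

Compound 4, `CC(=O)Oc1ccccc1C(=O)NCCSC#N`, is reached from compound 3 by a change on the carbonyl carbon that sits on the shared core: a group of 6 heavy atoms (3 carbon, 2 nitrogen, 1 sulfur; no ring) in place of a group of 6 heavy atoms (3 carbon, 1 nitrogen, 2 selenium; no ring), on a carbonyl carbon. Two things happen at once: the selenium attached to the carbonyl is replaced by nitrogen, giving an amide as in compound 1, and the cyanoselanyl end becomes a cyanosulfanyl end.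

For the measured compounds named here, the only measured step that bears on this is the reverse of the amide-to-selenoester change, a 4.4-fold higher number from compound 1 to compound 3 (0.64 log units; beyond the scatter). Reversing it should lower the number again. Going by the values given here, no measured compound tells how swapping selenium for sulfur at the chain end shifts the read-out, so that part is open.

Compound 4 is therefore expected to move back towards compound 1, by roughly a 3.6-fold lower number from compound 3 to compound 4 (0.56 log units; beyond the scatter), giving an estimate of 3500 nM with a range of 1200 nM to 10000 nM.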

Compound 4, half-maximal inhibitory concentration: > 50000 nM
Compound 4: only a limit was reported; the forecaster's own chance of this, stated with the estimate: 5%; at least 14-fold (1.15 log units) between middle value and limit.
By their numbers in this assay, from the lowest: compound 1; then compounds 3 and 2 (each within the scatter of the next). At a limit, above all of these: compound 4.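

In this assay compound 4 gives > 50000 nM, which is a limit of the assay and not a number. Keeping the amide and putting sulfur in place of selenium at the chain end gives a large step (an at least 17-fold higher number from compound 1 to compound 4 (1.23 log units; beyond the scatter)), so this one atom at the far end of the chain, well away from the carbonyl carbon, matters more than the earlier compounds could show. The amide alone does not secure activity, since compound 4 also reads higher than the two selenium compounds that lack an amide (an at least 3.9-fold higher number from compound 3 to compound 4 (0.59 log units; beyond the scatter)) and (an at least 2.8-fold higher number from compound 2 to compound 4 (0.45 log units; beyond the scatter)), while all three selenium compounds give measured numbers.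

On these data alone, the full size of these steps stays open, and so does whether selenium must sit in a cyanoselanyl end at all. A methylselanyl end, or a longer chain carrying the cyanoselanyl end, would speak to that.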